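This account rests on a few compounds, and the source may have more. Where it says the series, first, only, none or still open, it means among the compounds named here.

Measured so far in a functional assay on A-431 cells (Homo sapiens) for cytotoxicity, read by resazurin assay, with a stated time of 72 h; on this read-out lower numbers stand for stronger inhibition and higher numbers for weaker inhibition:
- compound 1, `CCCCOc1ccc(/N=c2\ssnc2Cl)cc1`: this compound reaches only the limit of the assay, > 100000 nM.
- compound 2, `N#CC1=Nc2c(c(-c3ccccc3)nn2Cc2ccccc2)SS1`: 54000 nM.

Within the data shown here, compound 2 holds the only numerical value in this assay; the one other result is a limit. the limit of > 100000 nM in this assay, at which 1 of the 2 values shown sits, marks where compound 1 sits, so no step between measured compounds can be stated, and the two values show only that compound 2 gives a number where compound 1 does not.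

The step to compound 3, `N#CC1=Nc2c(c(-c3ccccc3)nn2-c2ccccc2)SS1`, is phenyl in place of benzyl on an aromatic nitrogen. The fused core, the nitrile and the phenyl on the ring carbon stay as in compound 2. Among the measured compounds shown here, no measured pair in this assay shows what a change of this kind does, so the expectation rests on compound 2 alone and on the small size of the change.

The step from compound 2 to compound 3 is expected to stay within the scatter, a 1.0-fold higher number from compound 2 to compound 3 (0.01 log units; within the scatter). Compound 3 is therefore estimated at 55000 nM, with a range from 18000 nM to 160000 nM, and a real chance that this assay returns only a limit for it.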

Compound 3, half-maximal inhibitory concentration: 72000 nM
Estimate against measurement, compound 3: 1.3-fold (0.12 log units) below; measured number inside the range.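

In this assay, the aromatic nitrogen of the five-membered ring now has its first readable step, with phenyl in place of benzyl giving (a 1.3-fold higher number from compound 2 to compound 3 (0.12 log units; within the scatter)). At this position the two groups cannot be told apart on the present read-out, so the exchange of benzyl for phenyl leaves the number of the series where it was, within the usual scatter, and both compounds remain in the weak part of the range. Compound 3 also returns a real number, so compound 1 alone still holds a limit and not a number, and its steps to the other compounds cannot be read: the limit of > 100000 nM in this assay, at which 1 of the 3 values shown sits.

Among these compounds, the step covers only two groups with one six-membered aromatic ring of carbon only, so it remains open whether a small methyl, a chain ending in an amine or a ring carrying a carboxylic acid on this nitrogen would move the number beyond the scatter. Going by these compounds, the contribution of the nitrile and of the phenyl on the ring carbon also stays open, for instance with an amide in place of the nitrile.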